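Notes on para-substituent change in the phenyl series

A few compounds are considered here, and "the series" means these few. Any claim that something is new, unique, unknown or untested is made for them only; others in the source may bear on it.

Measured compounds:
compound 1 `CCNC(=O)c1cc(Oc2ccc(NC(=O)c3cc4cccnc4n(-c4ccccc4F)c3=O)cc2)ccn1`: 260 nM
compound 2 `CCNC(=O)c1cc(Oc2ccc(NC(=O)c3cc4cccnc4n(-c4ccc(F)cc4)c3=O)cc2)ccn1`: 190 nM

In a functional assay on HT-29 cells (Homo sapiens) for antiproliferative activity, read by MTT assay, with a stated time of 72 h (a lower number here means a stronger inhibitor, a higher number a weaker inhibitor), compound 2 gives the lowest of the two numbers. Its nearest neighbour is compound 1, and the step of a 1.4-fold lower number from compound 1 to compound 2 (0.14 log units; within the scatter) is within the scatter, so the two compounds cannot be ordered on this assay.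

Compound 3 `CCNC(=O)c1cc(Oc2ccc(NC(=O)c3cc4cccnc4n(-c4ccc(Cl)cc4)c3=O)cc2)ccn1` is not yet measured. It differs from compound 2 by chloro in place of fluoro on an aromatic carbon, that is, 4-fluorophenyl to 4-chlorophenyl on the aromatic nitrogen of the shared core. Among the measured compounds shown here, no measured step exchanges one halogen for another; the only step available, from compound 1 to compound 2, moves a fluoro between ring positions and stays within the scatter. On this basis a step of no more than the scatter is expected in this assay, with no direction supported by the data.

The expected value for compound 3 is 170 nM, with a range from 80 nM to 400 nM, the expected step being a 1.1-fold lower number from compound 2 to compound 3 (0.05 log units; within the scatter).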

Compound 3, half-maximal inhibitory concentration: 330 nM
Beside the measured number, compound 3's estimate is 1.9-fold (0.29 log units) below it; measured number inside the range.
By their numbers in this assay, from the lowest: compounds 2, 1 and 3 (each within the scatter of the next).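

In this assay, among the compounds shown here, the change from 4-fluorophenyl to 4-chlorophenyl gives the first halogen exchange, a 1.7-fold higher number from compound 2 to compound 3 (0.24 log units; within the scatter), so chloro and fluoro cannot be ordered at this position, para to a large group. Changing the halogen and its ring position together gives a 1.3-fold higher number from compound 1 to compound 3 (0.10 log units; within the scatter), and that double change also leaves the compounds unordered, so all three steps now available stay inside the scatter and no substituent trend can be drawn. Nothing in hand accounts for these numbers.

As far as these compounds go, it remains open whether a non-halogen group at this position, such as methoxy, an amine or a carboxylic acid, would move the number beyond the scatter. Whether a larger halogen, as in 4-bromophenyl, would do so is equally unsettled.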